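The source may hold more compounds than are shown below. What is called first, only, known or untested is meant among the compounds shown, and "the series" means these compounds.

Measured compounds:
Compound 1 `COc1ccc(-c2nnc(N3CCN(C(=O)CN4CCN(c5cccc(OC)c5)CC4)CC3)nc2-c2ccc(OC)cc2)cc1` — in a functional assay on MCF7 cells (Homo sapiens) for cytotoxicity, read by MTT assay, with a stated time of 24 h (a lower number here means a stronger inhibitor, a higher number a weaker inhibitor), compound 1 reaches only the assay limit, > 821000 nM.
Compound 2 `COc1ccc(-c2nnc(N3CCN(C(=O)CN4CCN(c5cccc(Cl)c5)CC4)CC3)nc2-c2ccc(OC)cc2)cc1` — in this assay compound 2 likewise reaches only the assay limit, > 814000 nM.

Within the data shown here, compound 2 thus stands at a limit in this assay, not at a number, and the one compound measured beside it stands at a limit as well (the limit of > 814000 nM in this assay, at which 1 of the 2 values shown sits; (the limit of > 821000 nM in this assay, at which 1 of the 2 values shown sits)). Among the measured compounds shown here, the only measured step, a step that the two limits leave unreadable from compound 1 to compound 2, is therefore of unknown size.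

Compound 3 `COc1ccc(-c2nnc(N3CCN(C(=O)CN4CCN(c5ccc(OC)cc5)CC4)CC3)nc2-c2ccc(OC)cc2)cc1` differs from compound 2 by 4-methoxyphenyl in place of 3-chlorophenyl on an amine nitrogen in a ring. It carries the same group that compound 1 carries, only in a different position on that ring. For the measured compounds named here, no measured step bears on this change with a readable size: the pair compound 1 and compound 2 gives two limits and nothing more. The expectation for compound 3 in this assay is therefore no step beyond the scatter, with compound 3 most likely again returning only a limit. Compound 3 is estimated at 1000000 nM (300000 nM to 3000000 nM), which means an expected step that the limit leaves unreadable from compound 2 to compound 3.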

Compound 3, half-maximal inhibitory concentration: > 821000 nM
Compound 3: a limit, no number; the forecaster's own chance of this, stated with the estimate: 85%; the middle value does not contradict the limit.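

In this assay compound 3 gives only a limit, > 821000 nM. Its steps from compound 1 and from compound 2 therefore cannot be read. The compounds shown leave open whether 3-methoxyphenyl, 3-chlorophenyl and 4-methoxyphenyl differ at all in this assay, and what value any of the three compounds would reach as a number.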